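This account rests on a few compounds, and the source may have more. Where it says the series, first, only, none or still open, it means among the compounds named here.

Three measured compounds, read in a functional assay on NCI-H1299 cells (Homo sapiens) for inhibition, read by CCK-8 assay, with a stated time of 72 h, tested at 10 uM; on this read-out higher numbers stand for a stronger effect at the one concentration tested and lower numbers for a weaker effect:
compound 1 `CN(C)C(=O)c1cc2cnc(Nc3ccc(S(=O)(=O)NCCCN=C=S)cc3)nc2n1C1CCCC1` gives 72.8%
compound 2 `CN(C)C(=O)c1cc2cnc(Nc3ccc(C(=O)NCCCN=C=S)cc3)nc2n1C1CCCC1` gives 91.2%
compound 3 `CN(C)C(=O)c1cc2cnc(Nc3ccc(NC(=O)CCCCN=C=S)cc3)nc2n1C1CCCC1` gives 82.5%

Compound 3 holds the second highest of the three numbers; the nearest step to it is a number 8.7 percentage points lower from compound 2 to compound 3 (within the scatter) and the furthest is a number 9.7 percentage points higher from compound 1 to compound 3 (within the scatter). Compound 4 `CN(C)C(=O)c1cc2cnc(Nc3ccc(NC(=O)CCCCCCN=C=S)cc3)nc2n1C1CCCC1` differs from compound 3 by a group of 5 heavy atoms (3 carbon, 1 nitrogen, 1 sulfur; no ring) in place of a group of 3 heavy atoms (1 carbon, 1 nitrogen, 1 sulfur; no ring), on a saturated chain carbon, four bonds along the chain from a carbonyl carbon. For the measured compounds named here, none of the measured steps alters the chain on its own: a number 18.4 percentage points higher from compound 1 to compound 2 (beyond the scatter) and a number 9.7 percentage points higher from compound 1 to compound 3 (within the scatter) exchange the whole linker, and a number 8.7 percentage points lower from compound 2 to compound 3 (within the scatter) exchanges linker and chain together while staying within the scatter. For compound 4 the step is therefore expected to stay within the scatter, a number 2.5 percentage points lower from compound 3 to compound 4 (within the scatter). Compound 4 is estimated at 80% in this assay, with a range from 65% to 92%.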

Compound 4, a percentage reported as inhibition, at one concentration (the size of the read-out at that concentration, not a potency): 80.9%
The estimate for compound 4 lay 0.9 percentage points below the measured number; measured number inside the range.
By their numbers in this assay, from the lowest: compounds 1, 4, 3 and 2 (each within the scatter of the next, the first and the last beyond it).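

In this assay, for the compounds shown here, the step of a number 1.6 percentage points lower from compound 3 to compound 4 (within the scatter) is the first to alter the chain alone, so the longer chain shows no resolved effect at this position. The step of a number 10.3 percentage points lower from compound 2 to compound 4 (beyond the scatter) stands apart from the step of a number 8.1 percentage points higher from compound 1 to compound 4 (within the scatter) in that only the first lies beyond the scatter, so compound 4 separates from compound 2 where compound 3 did not. No evidence is available to explain these numbers. The compounds shown leave open whether a still longer chain or an amine on the chain would change the number here.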